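This account rests on a few compounds, and the source may have more. Where it says the series, first, only, none or still open, it means among the compounds named here.

Compound 2 `C[C@@H](O[C@@H]1[C@@H](c2ccccc2)CN2C(=O)OC[C@H]12)c1cc(C(F)(F)F)cc(C(F)(F)F)c1` gives 1.5 nM in an assay on CHO cells for displacement of a labelled ligand from Substance-P receptor (Homo sapiens) (a higher number here means a weaker inhibitor, a lower number a stronger inhibitor), the highest of the three numbers measured. Compound 3 `C[C@@H](O[C@@H]1[C@@H](c2ccc(F)cc2)CN2C(=O)OC[C@H]12)c1cc(C(F)(F)F)cc(C(F)(F)F)c1` gives 1 nM and compound 1 `C[C@@H](O[C@@H]1[C@@H](c2ccc(F)cc2)CN2C(=O)OC[C@@H]12)c1cc(C(F)(F)F)cc(C(F)(F)F)c1` gives 0.33 nM. The step of a 1.5-fold lower number from compound 2 to compound 3 (0.18 log units; within the scatter) lies within the scatter, whereas a 3.0-fold higher number from compound 1 to compound 3 (0.48 log units; beyond the scatter) lies beyond it, and that last step rests on (the fact that compounds 1 and 3 differ only in the configuration as drawn). Compound 4 `C[C@@H](O[C@@H]1[C@@H](c2ccccc2)CN2C(=O)OC[C@@H]12)c1cc(C(F)(F)F)cc(C(F)(F)F)c1` stands to compound 2 as compound 1 stands to compound 3, with the configuration reversed: the two compounds have the same atoms and bonds and differ only in configuration as drawn: 1 of 4 stereo elements differ; a stereocentre at a saturated ring carbon is drawn R in compound 2 and S in compound 4. Among the measured compounds shown here, the one comparable step, a 3.0-fold higher number from compound 1 to compound 3 (0.48 log units; beyond the scatter), ran the other way, so a lower number of similar size is expected here, roughly a 3.0-fold lower number from compound 2 to compound 4 (0.48 log units; beyond the scatter). For compound 4 the estimate in this assay is 0.5 nM, in the range 0.25 nM to 1 nM.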

Compound 4, half-maximal inhibitory concentration: 1.3 nM
Beside the measured number, compound 4's estimate is 2.6-fold (0.41 log units) below it; the whole stated range lies below it.
By their numbers in this assay, from the lowest: compound 1; then compounds 3, 4 and 2 (each within the scatter of the next).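

Without the fluoro group, reversing this ring carbon in this assay gives a 1.2-fold lower number from compound 2 to compound 4 (0.06 log units; within the scatter), whereas with the fluoro group the same reversal gives a 3.0-fold higher number from compound 1 to compound 3 (0.48 log units; beyond the scatter). So among these four compounds, the configuration at this position separates only the fluoro pair. Fluoro replaced by hydrogen on the S-drawn core gives a 3.9-fold higher number from compound 1 to compound 4 (0.60 log units; beyond the scatter), yet the two fluoro steps cannot be told apart: the same change on two cores in this assay, a 1.5-fold lower number (0.18 log units; within the scatter) from compound 2 to compound 3 and a 3.9-fold lower number (0.60 log units; beyond the scatter) from compound 4 to compound 1, 2.6-fold (0.42 log units) apart, within the scatter of two such steps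

On these data alone, whether a chloro or methoxy group in place of the fluoro would behave the same way on either configuration remains open.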